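From propyl to 1-methylethenyl on the chain carbon

The compounds below may be only part of what the source reports. "The series", "measured", "known", "first", "only" and "open" are said of these compounds alone.

Among the compounds with values here, compound 2 `CCCCn1cc(CO[C@H]2CC(=O)[C@@H]3OC[C@H]2O3)nn1` is the only compound with a number in a functional assay on MDA-MB-231 cells (Homo sapiens) for cytotoxicity, read by MTT assay, with a stated time of 48 h (on this read-out higher numbers stand for weaker inhibition and lower numbers for stronger inhibition), where compound 2 gives 27900 nM. Compound 1 `O=C1C[C@H](OCc2cn(Cc3ccccc3)nn2)[C@H]2CO[C@@H]1O2` reaches only a limit of > 50000 nM in this assay. Within the data shown here, the single measured step, an at least 1.7-fold lower number from compound 1 to compound 2 (0.25 log units; that floor lies within the scatter), is therefore bounded on one side by the limit of > 50000 nM in this assay, at which 1 of the 2 values shown sits, and its floor tells little about how far the two compounds really differ. Compound 3 `C=C(C)Cn1cc(CO[C@H]2CC(=O)[C@@H]3OC[C@H]2O3)nn1` differs from compound 2 by 1-methylethenyl in place of propyl on a saturated chain carbon bound to an aromatic nitrogen. The measured step also exchanged one group at the same place, yet it gives no firm size to carry over, so the change to a 1-methylethenyl group is expected to move the number by no more than the scatter. Compound 3 is thus expected to show a step of a 1.1-fold lower number from compound 2 to compound 3 (0.05 log units; within the scatter). Compound 3 is estimated at 25000 nM, between 8000 nM and 80000 nM.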

Compound 3, half-maximal inhibitory concentration: 26700 nM
Compound 3: middle estimate off by 1.1-fold (0.03 log units), on the low side, within the range that was stated.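

In this assay, the exchange on a saturated chain carbon bound to an aromatic nitrogen gives a 1.0-fold lower number from compound 2 to compound 3 (0.02 log units; within the scatter), so a double bond outside aromatic rings enters this place with no shift beyond the scatter. Within the data shown here, this is the first step measured between two numbers rather than against a limit, and compound 2 and compound 3 read alike. The exchange of phenyl for 1-methylethenyl at the same place gives an at least 1.8-fold lower number from compound 1 to compound 3 (0.27 log units; that floor lies within the scatter), and that size is only a floor because one end of the step is a limit: the limit of > 50000 nM in this assay, at which 1 of the 3 values shown sits.

The compounds shown leave open whether another group at this place, such as a longer chain, an amine or a carboxylic acid, would move the number beyond the scatter. They also leave open how far compound 1 truly lies from compound 2 and compound 3, and whether changes on the shared core would matter.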